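Cytotoxicity notes: chloro in place of methyl

The source may hold more compounds than are shown below. What is called first, only, known or untested is meant among the compounds shown, and "the series" means these compounds.

Among the measured compounds shown here, the series so far holds two measured compounds, compound 1 `O=[N+]([O-])c1ccc(-c2nnc(-c3cccnc3)n2Nc2nc3ccc(Br)cc3s2)cc1` and compound 2 `Cc1ccc2nc(Nn3c(-c4ccc([N+](=O)[O-])cc4)nnc3-c3cccnc3)sc2c1`. In an ADME assay on MT4 cells (Homo sapiens) for cytotoxicity, read by MTT assay, with a stated time of 5 days (a lower number here means that less compound is tolerated, a higher number that more compound is tolerated), compound 1 gives 13.2 ug/mL, and compound 2 gives 64.4 ug/mL. For the measured compounds named here, the single step between them, a 4.9-fold higher number from compound 1 to compound 2 (0.69 log units; beyond the scatter), is modest but beyond the scatter. Going by the values given here, compound 2 therefore stands highest of the two numbers, with compound 1 as its only neighbour at a lower number.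

Compound 3 `O=[N+]([O-])c1ccc(-c2nnc(-c3cccnc3)n2Nc2nc3ccc(Cl)cc3s2)cc1` is not yet measured. Relative to compound 2 the change is chloro in place of methyl on an aromatic carbon, that is, 6-methyl-1,3-benzothiazol-2-yl becoming 6-chloro-1,3-benzothiazol-2-yl. Among the compounds with values here, the one measured step that bears on it is a 4.9-fold higher number from compound 1 to compound 2 (0.69 log units; beyond the scatter), read in reverse: there a bromo gave way to the methyl and the number rose. Going the other way, from methyl back to a halogen, a drop of similar size is the natural expectation, though chloro is not bromo and no step between the two halogens has been measured. Compound 3 is therefore expected to show a lower number in this assay, roughly a 3.2-fold lower number from compound 2 to compound 3 (0.51 log units; beyond the scatter). The estimate for compound 3 is 20 ug/mL, within 8 ug/mL to 50 ug/mL.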

Compound 3, half-maximal cytotoxic concentration: 53.7 ug/mL
The estimate for compound 3 lay 2.7-fold (0.43 log units) below the measured number; measured number outside the range, above it.
By their numbers in this assay, from the lowest: compound 1; then compounds 3 and 2 (each within the scatter of the next).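

Swapping 6-methyl-1,3-benzothiazol-2-yl for 6-chloro-1,3-benzothiazol-2-yl gives a 1.2-fold lower number from compound 2 to compound 3 (0.08 log units; within the scatter) in this assay, so methyl and chloro cannot be told apart at this position in this read-out. The halogen comparison, chloro in place of bromo on the same aromatic carbon, gives a 4.1-fold higher number from compound 1 to compound 3 (0.61 log units; beyond the scatter), which shows that the step seen earlier does not separate halogens as a class from methyl: among these three compounds, bromo alone stands apart, and neither of the other two compounds goes against that reading. Nothing available explains why bromo differs from chloro here.

From the compounds shown here alone, three substituents at one position are too few to show what sets bromo apart, and it remains open whether a fluoro, a methoxy or an amine at this place would group with chloro and methyl or with bromo. Going by these compounds, it is also open whether the same grouping would hold if the nitro group on the other side of the shared core gave way to a carboxylic acid.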